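Swapping cyclohexyl for phenyl on a weak antagonist

A few compounds are considered here, and "the series" means these few. Any claim that something is new, unique, unknown or untested is made for them only; others in the source may bear on it.

Of the compounds shown here, two have so far been measured in an in vitro functional assay on HEK ts201 cells for antagonist activity at Neuronal acetylcholine receptor; alpha4/beta2 (Homo sapiens), read by fluorescence and calcium flux; on this read-out higher numbers stand for weaker inhibition and lower numbers for stronger inhibition. Compound 1, `[N-]=[N+]=NCCCN1CCCC(COC(=O)c2ccccc2-c2ccccc2)C1`, gives 4270 nM in this assay. Compound 2, `CC1CC(=O)N(c2ccccc2C(=O)OC[C@@H]2C[C@H](C3CCCCC3)CN(CCCc3ccccc3)C2)C1=O`, gives 39800 nM in this assay, the higher of the two numbers and clearly apart from the number of compound 1, beyond the usual scatter of repeated measurements. Compound 3, `CC1CC(=O)N(c2ccccc2C(=O)OC[C@@H]2C[C@H](c3ccccc3)CN(CCCc3ccccc3)C2)C1=O`, has not yet been measured. It differs from compound 2 in one place only: phenyl in place of cyclohexyl on a saturated ring carbon. Among the compounds with values here, compound 1 and compound 2 differ from each other in many places at once, so their two values give no guide to what this single exchange of one six-membered ring for another might do, and no measured pair shows such an exchange on this shared core. With nothing further to rest on, the expected step of a 1.3-fold lower number from compound 2 to compound 3 (0.12 log units; within the scatter) is small, in either direction or none beyond the scatter. Compound 3 is therefore estimated at 30000 nM in this assay, with a range from 8000 nM to 100000 nM.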

Compound 3, half-maximal inhibitory concentration: 5370 nM
Compound 3: the middle estimate sits 5.6-fold (0.75 log units) above what was measured, and the stated range ends above it.
By their numbers in this assay, from the lowest: compounds 1 and 3 (each within the scatter of the next); then compound 2.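

In this assay, the saturated ring carbon on the shared core proves sensitive to which six-membered ring it carries: phenyl in place of cyclohexyl gives a 7.4-fold lower number from compound 2 to compound 3 (0.87 log units; beyond the scatter) and so stronger inhibition. The two groups have the same count of heavy atoms, and neither has a hydrogen-bond donor, a hydrogen-bond acceptor or a net charge, so by these counts the clear difference is that the entering ring is aromatic and the leaving ring is not. Nothing available here shows why this exchange lowers the number.

This single pair cannot tell whether the gain extends to aromatic rings in general or belongs to phenyl alone, nor whether it would carry over to a different core. A pyridyl ring, which places a nitrogen inside the aromatic ring, or a much smaller methyl group on the same ring carbon would be informative next steps, since either would help show how much of the ring this position needs.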